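Compound 1 to Compound 4: Swapping a Side Group

The source may report more compounds than this note shows. Statements on the series, on what has been measured and on what is new or still open speak of the compounds shown alone.

Going by the values given here, in a functional assay on KYSE-450 cells (Homo sapiens) for inhibition, read by CCK-8 assay, with a stated time of 48 h (a higher number here means a weaker inhibitor, a lower number a stronger inhibitor), compound 1 `COc1ccc(CN(C(=O)CSC(=S)N2CCN(C)CC2)c2cc(OC)c(OC)c(OC)c2)cc1` gives 1250 nM, the strongest inhibition among the three compounds measured so far. Compound 2 `COc1ccc(CN(C(=O)CSC(=S)N2CCCc3cc(C)ccc32)c2cc(OC)c(OC)c(OC)c2)cc1` gives 5210 nM. Compound 3 `COc1ccc(CN(C(=O)CSC(=S)N2CCc3ccccc3C2)c2cc(OC)c(OC)c(OC)c2)cc1` reaches only a limit of the assay, > 20000 nM.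

Compound 4 `CCN1CCN(CC(=O)N(Cc2ccc(OC)cc2)c2cc(OC)c(OC)c(OC)c2)CC1` keeps the core of compound 1 but changes what sits on a saturated chain carbon bound to a carbonyl carbon: a group of 8 heavy atoms (6 carbon, 2 nitrogen; one six-membered non-aromatic ring with 2 hetero atoms) in place of a group of 10 heavy atoms (6 carbon, 2 nitrogen, 2 sulfur; one six-membered non-aromatic ring with 2 hetero atoms), on a saturated chain carbon bound to a carbonyl carbon. The measured steps bear on this only indirectly, since each exchanges a group on a thiocarbonyl carbon and the thiocarbonyl itself stays. Replacing 4-methylpiperazin-1-yl gave a 4.2-fold higher number from compound 1 to compound 2 (0.62 log units; beyond the scatter), a modest step, and an at least 16-fold higher number from compound 1 to compound 3 (1.20 log units; beyond the scatter), a large one. Among the compounds with values here, compound 4 keeps a six-membered non-aromatic ring with 2 hetero atoms, but no measured step shows what losing the sulfur-bearing link does. A modest move towards weaker inhibition therefore seems most likely, with an expected step of a 2.8-fold higher number from compound 1 to compound 4 (0.45 log units; beyond the scatter). For compound 4, the estimated value is 3500 nM, with an expected range from 800 nM to 15000 nM.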

Compound 4, half-maximal inhibitory concentration: 16100 nM
Compound 4: middle estimate off by 4.6-fold (0.66 log units), on the low side; the measured number lies above the stated range.
By their numbers in this assay, from the lowest: compound 1; then compound 2; then compound 4. At a limit, above all of these: compound 3.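

In this assay, the change to 4-ethylpiperazin-1-yl gives a 13-fold higher number from compound 1 to compound 4 (1.11 log units; beyond the scatter), so keeping a six-membered non-aromatic ring with 2 hetero atoms on a saturated chain carbon bound to a carbonyl carbon does not keep the inhibition of compound 1. Going by these compounds alone, this is the first measured change in which both sulfur atoms leave, whereas the earlier steps all kept the thiocarbonyl and exchanged only the group on it. Compound 3 remains the only compound at a limit of the assay, and compound 4 still gives a number: the limit of > 20000 nM in this assay, at which 1 of the 4 values shown sits.

The ring substituent also differs, ethyl in compound 4 and methyl in compound 1. The data do not separate this difference from the departure of the sulfur atoms. Going by these compounds, how a morpholin-4-yl group would behave on this chain carbon also remains open.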